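Adding a Methoxy Group to the Benzyl Ring of Compound 3

A few compounds are considered here, and "the series" means these few. Any claim that something is new, unique, unknown or untested is made for them only; others in the source may bear on it.

Measured compounds:
Compound 1 `O=S(=O)(NCCCCNCc1ccc(Br)cc1)c1cc(C(F)(F)F)cc(C(F)(F)F)c1` gives 2200 nM in a functional assay on BE(2)-C cells (Homo sapiens) for inhibition, read by MTT assay, with a stated time of 72 h; on this read-out lower numbers stand for stronger inhibition of growth and higher numbers for weaker inhibition of growth.
Compound 2 `O=S(=O)(NCCCNCC1COc2ccccc2O1)c1cc(C(F)(F)F)cc(C(F)(F)F)c1` gives 2800 nM.
Compound 3 `O=S(=O)(NCCCNCc1ccccc1)c1cc(C(F)(F)F)cc(C(F)(F)F)c1` gives 12000 nM.

Compound 3 carries the highest number of the three in this assay, so it is the weakest inhibitor of growth among them; compound 2 is its nearest neighbour and compound 1 lies furthest away. Compound 4 `COc1ccc(CNCCCNS(=O)(=O)c2cc(C(F)(F)F)cc(C(F)(F)F)c2)cc1` differs from compound 3 by methoxy in place of hydrogen on an aromatic carbon of the benzyl ring.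

Going by the values given here, two measured steps bear on this change: a 5.5-fold higher number from compound 1 to compound 3 (0.74 log units; beyond the scatter) and a 4.3-fold higher number from compound 2 to compound 3 (0.63 log units; beyond the scatter). In both, the bare benzyl group of compound 3 gave a higher number than a benzyl ring bearing a substituent or a fused ring. Neither step introduces a methoxy group, so the size of its effect is not directly known, but both point the same way: decorating the benzyl ring lowered the number by a modest amount.

Compound 4 is therefore expected to show a modestly lower number than compound 3, estimated as a 2.4-fold lower number from compound 3 to compound 4 (0.38 log units; beyond the scatter).

Compound 4 is estimated at 5000 nM, with a range from 2000 nM to 12000 nM.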

Compound 4, concentration for 50% growth inhibition: 2800 nM
The estimate for compound 4 lay 1.8-fold (0.25 log units) above the measured number, within the range that was stated.
By their numbers in this assay, from the lowest: compounds 1, 2 and 4 (each within the scatter of the next); then compound 3.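

In this assay, going by these compounds alone, the change from compound 3 to compound 4 is the first step here that adds a single group to the benzyl ring and alters nothing else: methoxy replaces hydrogen on an aromatic carbon, para to a large group, and the result is a 4.3-fold lower number from compound 3 to compound 4 (0.63 log units; beyond the scatter). This one added group also brings the benzyl series level with the two more heavily changed compounds, with no change at the digits printed from compound 2 to compound 4 (within the scatter) and a 1.3-fold higher number from compound 1 to compound 4 (0.10 log units; within the scatter), so compound 3 now stands alone as the weakest inhibitor of growth among the four. No measurement shown here accounts for the drop in the number from this single change.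

On these data alone, it remains open whether the gain belongs to methoxy itself or would also come with another group on the same carbon, such as a hydroxyl, a nitrile or an amine. It is also unknown how a methoxy group would behave on a different carbon of the ring, since every step here speaks only to this one place.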